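Swapping 3,4-dichlorophenyl for sec-butoxy in a flat series

The compounds below may be only part of what the source reports. "The series", "measured", "known", "first", "only" and "open" are said of these compounds alone.

Compound 1 (`O=C(Nc1ccc(O)c2c(=O)cc(-c3ccccc3Cl)oc12)c1ccc(Cl)c(Cl)c1`) gives 15000 nM in a functional assay on MCF7 cells (Homo sapiens) for antiproliferative activity (a lower number here means a stronger inhibitor, a higher number a weaker inhibitor), and has close company on that measure. Compound 2 (`O=C(Nc1c(O)cc(O)c2c(=O)cc(-c3ccccc3Cl)oc12)c1ccc(Cl)cc1`) gives 13000 nM in this assay and compound 3 (`CSCC[C@H](NC(=O)OC(C)(C)C)C(=O)Nc1ccc(O)c2c(=O)cc(-c3ccccc3Cl)oc12`) gives 20000 nM there. All three numbers lie within the usual scatter of one another, so compound 1 stands level with both.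

The unmeasured compound 4 (`CCC(C)OC(=O)Nc1ccc(O)c2c(=O)cc(-c3ccccc3Cl)oc12`) keeps the core of compound 1 and has sec-butoxy in place of 3,4-dichlorophenyl on a carbonyl carbon so the aromatic ring of that group is lost. Within the data shown here, no measured pair isolates this swap. Unlike compound 1, compound 3 carries a different group on that carbonyl and still gives 20000 nM in this assay so no step beyond the scatter is expected, in either direction. The estimated step is a 1.2-fold higher number from compound 1 to compound 4 (0.08 log units; within the scatter) and would count as no real change. In this assay the estimate for compound 4 is 18000 nM (expected range 8000 nM to 40000 nM).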

Compound 4, half-maximal inhibitory concentration: 30000 nM
For compound 4 the middle estimate is 1.7-fold (0.22 log units) below the measured one; low and high end bracket the measured number.
By their numbers in this assay, from the lowest: compounds 2, 1, 3 and 4 (each within the scatter of the next, the first and the last beyond it).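

Among these compounds, this is the first pair that isolates the carbonyl substituent, and in this assay the step is a 2.0-fold higher number from compound 1 to compound 4 (0.30 log units; within the scatter), which lies within the scatter. On this one pair, then, the 3,4-dichlorophenyl group can give way to sec-butoxy, with its aromatic ring gone and no ring in its place, without a real change in the read-out. No measurement shown here accounts for this result.

As far as these compounds go, whether a carbonyl substituent carrying an amine or a carboxylic acid would stay level with compound 1 remains open. So does whether any group on this carbonyl carbon can move the number beyond the scatter on the core of compound 1.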